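A dichlorobenzyl swap on a scaffold that has shown no activity

This account rests on a few compounds, and the source may have more. Where it says the series, first, only, none or still open, it means among the compounds named here.

Compound 1 `COc1ccc(-n2cc(CSC(=S)N3CCN(C(=O)OC(C)(C)C)CC3)nn2)cc1` was tested in a functional assay on PC-3 cells (Homo sapiens) for inhibition, read by MTT assay, with a stated time of 72 h (a lower number here means a stronger inhibitor, a higher number a weaker inhibitor), and gave only a limit, > 128000 nM. Compound 2 `Fc1ccc(Cn2cc(CSC(=S)N3CCNCC3)nn2)cc1` likewise gave only a limit in this assay, namely > 128000 nM. Both results shown thus sit at the limit of > 128000 nM in this assay, at which 2 of the 2 values shown sit, so compound 1 stands at the edge of what this assay can report, with no number to compare. Compound 3 `CC(C)(C)OC(=O)N1CCN(C(=S)SCc2cn(Cc3ccc(Cl)c(Cl)c3)nn2)CC1` differs from compound 1 by 3,4-dichlorobenzyl in place of 4-methoxyphenyl on an aromatic nitrogen. Within the data shown here, with no measured step to draw on, the step of an at least 1.1-fold lower number from compound 1 to compound 3 (0.06 log units; that floor lies within the scatter) is expected to be small, within the scatter, and is an estimate only. Compound 3 is therefore estimated at 110000 nM, within a range of 30000 nM to 250000 nM, most likely again reported as a limit.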

Compound 3, half-maximal inhibitory concentration: > 128000 nM
Compound 3 ended at the assay's limit; the forecaster's own chance of this, stated with the estimate: 70%; middle value at least 1.1-fold (0.06 log units) from the limit.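

Compound 3, like compound 1, gave only a limit in this assay, so no step can be read between them: the limit of > 128000 nM in this assay, at which 3 of the 3 values shown sit.

The compounds shown leave open whether 3,4-dichlorobenzyl in place of 4-methoxyphenyl changes anything, and whether any of them has a measurable value in this assay.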